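Replacing trifluoromethyl in compound 1

The source may report more compounds than this note shows. Statements on the series, on what has been measured and on what is new or still open speak of the compounds shown alone.

Among the compounds with values here, in an in vitro ADME assay on microsomes from liver (Homo sapiens) for metabolic stability (on this read-out higher numbers stand for fast clearance and lower numbers for slow clearance), compound 1 `COCc1nc2nc(C)cc(Nc3ccc(C(F)(F)F)cc3)n2n1` gives 6.7 mL.min-1.g-1, the only exact number so far. Its close relative, compound 2 `Cc1cc(Nc2ccc(C(F)(F)F)cc2)n2nc(CCO)nc2n1`, gives < 5 mL.min-1.g-1, which is a limit of the assay and not a number.

Compound 3 `COCc1nc2nc(C)cc(Nc3ccc(S(F)(F)(F)(F)F)cc3)n2n1` keeps the core of compound 1 and alters one group: a group of 6 heavy atoms (5 fluorine, 1 sulfur; no ring) in place of a group of 4 heavy atoms (1 carbon, 3 fluorine; no ring), on an aromatic carbon. The trifluoromethyl leaves an aromatic carbon, and a group of five fluorine atoms and one sulfur takes its place. Within the data shown here, only one measured step is available, an at least 1.3-fold lower number from compound 1 to compound 2 (0.12 log units; that floor lies within the scatter). It changes a different part of the molecule and leaves the trifluoromethyl untouched, so it offers only weak guidance here. Among the measured compounds shown here, with no measured step at this place, no shift beyond the scatter is expected in this assay, and no direction can be favoured. The expected step is a 1.0-fold higher number from compound 1 to compound 3 (0.02 log units; within the scatter). For compound 3 the estimated value is 7 mL.min-1.g-1, with an expected range from 4 mL.min-1.g-1 to 14 mL.min-1.g-1.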

Compound 3, intrinsic clearance in microsomes: 5.6 mL.min-1.g-1
The estimate for compound 3 lay 1.3-fold (0.10 log units) above the measured number, within the range that was stated.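

In this assay, within the data shown here, the first measured change at this place on the aromatic ring, the group of 5 fluorine and 1 sulfur in place of trifluoromethyl, gives a 1.2-fold lower number from compound 1 to compound 3 (0.08 log units; within the scatter). This position therefore accepts the larger group without a shift beyond the scatter, so the read-out does not tell these two groups apart on this core. The values shown also lie close to the lowest value this assay reports, which leaves little room to see any further fall in clearance: the limit of < 5 mL.min-1.g-1 in this assay, at which 1 of the 3 values shown sits.

Still open, going by these compounds, is whether a group of another kind at this place, such as an amine, a carboxylic acid or a nitrile, would move the number beyond the scatter. Also open, on these data alone, is whether the same swap would give a readable result alongside the side chain of compound 2.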